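This account rests on a few compounds, and the source may have more. Where it says the series, first, only, none or still open, it means among the compounds named here.

Working notes on the series. Compound 1 `O=C1OC[C@H](Cc2ccccc2)[C@H]1Cc1ccccc1` is the unsubstituted member. In a functional assay on HL-60 cells (Homo sapiens) for cytotoxicity, read by WST assay, with a stated time of 48 h (on this read-out lower numbers stand for an effect already at smaller amounts and higher numbers for an effect only at larger amounts of compound), compound 1 gives 77000 nM, the highest of the two numbers measured, though only by a margin inside the scatter. In this assay compound 2 `COCOc1ccccc1C[C@H]1C(=O)OC[C@@H]1Cc1ccccc1` gives 76000 nM. For the measured compounds named here, the one step measured so far, a 1.0-fold lower number from compound 1 to compound 2 (0.01 log units; within the scatter), methoxymethoxy in place of hydrogen on an aromatic carbon, was flat. Compound 3 `O=C1OC[C@H](Cc2ccccc2)[C@H]1Cc1cccc(O)c1` is not yet measured in this assay. It differs from compound 1 by hydroxy in place of hydrogen on an aromatic carbon; cut one bond further out, phenyl to 3-hydroxyphenyl. Going by the values given here, the only step that bears on it is a 1.0-fold lower number from compound 1 to compound 2 (0.01 log units; within the scatter), also an oxygen substituent entering on an aromatic carbon, and it stayed within the scatter. On that basis no shift beyond the scatter is expected, no change at the digits printed from compound 1 to compound 3 (within the scatter), for compound 3. Compound 3 is estimated at 77000 nM in this assay, within 38000 nM to 154000 nM.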

Compound 3, half-maximal effective concentration: > 100000 nM
Compound 3: a limit, no number; the forecaster's own chance of this, stated with the estimate: 10%; middle value at least 1.2-fold (0.11 log units) away from the limit.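

In this assay compound 3 gives > 100000 nM, which is a limit of the assay and not a number. For the compounds shown here, the step reads an at least 1.2-fold higher number from compound 1 to compound 3 (0.11 log units; that floor lies within the scatter), so this is the first change on an aromatic carbon, here meta to a large group, that gives a limit rather than a number, and hydroxy at this place brings no lower number than hydrogen. Among the compounds shown, this change alone reaches that limit: the limit of > 100000 nM in this assay, at which 1 of the 3 values shown sits.

On these data alone, whether the true number of compound 3 lies within the scatter of compound 1 or well beyond it stays open, as only a floor is available. Also open, as far as these compounds go, is whether an amine or a carboxylic acid in place of hydroxy at this position would give a measurable number in this read-out, and whether either would differ from compound 1 beyond the scatter.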